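The compounds below may be only part of what the source reports. "The series", "measured", "known", "first", "only" and "open" are said of these compounds alone.

Compound 1, with the structure `CCOC(=O)C1c2c[nH]nc2CCN1S(=O)(=O)c1ccc(Cl)cc1`, is the starting point of this account. In an ADME assay on microsomes from liver (Homo sapiens) for metabolic stability, using NADPH, with a stated time of 30 min, in the presence of a further agent that is not named here (a higher number here means that more of the compound is left, a lower number that less of the compound is left), compound 1 gives 1%, the lowest of the three numbers recorded, though its gaps to the other two lie within the scatter. Compound 2, `O=S(=O)(c1ccc(Cl)cc1)N1Cc2c[nH]nc2CC1c1ccccc1`, gives 5% in this assay, and compound 3, `O=S(=O)(c1ccc(Cl)cc1)N1Cc2c[nH]nc2CC1c1ccc(F)cc1`, gives 6%. Within the data shown here, the one step recorded, a number 1 percentage points higher from compound 2 to compound 3 (within the scatter), involves a fluoro in place of hydrogen on an aromatic carbon and is within the scatter. Compound 4, `O=S(=O)(c1ccc(Cl)cc1)N1CCc2n[nH]cc2C1c1cncnc1`, has not yet been measured; it differs from compound 1 by pyrimidin-5-yl in place of ethoxycarbonyl on a saturated ring carbon. Among the measured compounds shown here, no recorded step concerns a change of this kind, and the step from compound 2 to compound 3 tells nothing about it. All three measured compounds sharing this core sit at low values, so no step beyond the scatter is expected in this assay. Compound 4 is estimated to give 8%, between 2% and 25%, an expected step of a number 7 percentage points higher from compound 1 to compound 4 (within the scatter).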

Compound 4, percent of the compound remaining: 50%
Compound 4: middle estimate off by 42 percentage points, on the low side; the measured number lies above the stated range.
By their numbers in this assay, from the lowest: compounds 1, 2 and 3 (each within the scatter of the next); then compound 4.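

On the saturated ring carbon next to the ring nitrogen, pyrimidin-5-yl in place of ethoxycarbonyl gives, in this assay, a number 49 percentage points higher from compound 1 to compound 4 (beyond the scatter) for this single change. This is the first step recorded beyond the scatter in this series, as the only earlier step, on an aromatic carbon of a different compound pair, stayed within it, so this saturated ring carbon is shown to be a place where a change can move the amount of compound left by a large margin. Nothing available explains the size of this step, and no measurement bears on its cause.

The compounds shown do not separate what the departure of ethoxycarbonyl contributes from what the arrival of pyrimidin-5-yl contributes. Going by these compounds, whether a carboxylic acid, an amide or a pyridin-3-yl on the same carbon would give a similar number remains open.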